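The source may hold more compounds than are shown below. What is called first, only, known or untested is meant among the compounds shown, and "the series" means these compounds.

Compound 1 `CCOc1ccc(Br)cc1C(C)NC(=O)N(C)S(=O)(=O)c1ccc(Cl)cc1`, compound 2 `CCOc1ccc(Br)cc1C(C)NC(=O)NS(=O)(=O)c1ccc(Cl)cc1` and compound 3 `COc1ccc(F)cc1C(C)NC(=O)NS(=O)(=O)c1ccc(C)cc1` have been tested in a functional assay on thoracic aorta (Rattus norvegicus, strain Wistar), with a stated time of 15 min; on this read-out higher numbers stand for an effect only at larger amounts of compound and lower numbers for an effect already at smaller amounts. In this assay compound 1 gives 55700 nM. Compound 2 gives 171000 nM in this assay. For compound 3 this assay reports only a limit, > 300000 nM.

Compound 1 and compound 2 differ in one place, namely (methyl in place of hydrogen on an amide-type nitrogen), and this change produced a 3.1-fold lower number from compound 2 to compound 1 (0.49 log units; beyond the scatter). How the core of compound 3 differs from the core of compound 2 is not broken down here.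

Compound 4 `COc1ccc(F)cc1C(C)NC(=O)N(C)S(=O)(=O)c1ccc(C)cc1` has not yet been measured. Going by the values given here, it differs from compound 3 by methyl in place of hydrogen on an amide-type nitrogen, which is the same change as the one from compound 2 to compound 1, with the place described in the same words. Because compound 3 sits at the limit (the limit of > 300000 nM in this assay, at which 1 of the 3 values shown sits), the starting point for compound 4 is itself uncertain. For compound 4 the expected step is an at least 1.6-fold lower number from compound 3 to compound 4 (0.22 log units; that floor lies within the scatter), resting on a 3.1-fold lower number from compound 2 to compound 1 (0.49 log units; beyond the scatter). Compound 4 is therefore estimated to give about 180000 nM in this assay, most likely between 50000 nM and 500000 nM.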

Compound 4, half-maximal effective concentration: 11700 nM
Beside the measured number, compound 4's estimate is 15-fold (1.19 log units) above it, outside the stated range (below it).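

In this assay methyl in place of hydrogen on the amide-type nitrogen gives an at least 25-fold lower number from compound 3 to compound 4 (1.40 log units; beyond the scatter), so the number falls on both cores shown. The direction of the change carried over from one core to the other, but its size did not: the same change on two cores in this assay, a 3.1-fold lower number (0.49 log units; beyond the scatter) from compound 2 to compound 1 and an at least 25-fold lower number (1.40 log units; beyond the scatter) from compound 3 to compound 4, at least 8.3-fold (0.92 log units) apart, beyond the scatter of two such steps. Going by these compounds, compound 3 is known only through a limit, so the true size of this step stays unknown and the result gives only its smallest possible size: the limit of > 300000 nM in this assay, at which 1 of the 4 values shown sits.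

The cores of compound 2 and compound 3 differ in more than one place, so the compounds shown leave open which part of the core goes with the larger step. They also leave open whether the step would hold on a further core, and whether an ethyl group or a longer chain on that nitrogen would act as methyl does.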